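Nitro in Place of Amino at a Cytotoxicity Limit

A few compounds are considered here, and "the series" means these few. Any claim that something is new, unique, unknown or untested is made for them only; others in the source may bear on it.

Compound 1, `Cc1cc(S(=O)(=O)N2C(=O)N[C@@H](c3ccccc3)C2C)ccc1NC(=O)c1ccc([N+](=O)[O-])cc1`: > 10000 nM
Compound 2, `CCOC(=O)Nc1ccc(S(=O)(=O)N2C(=O)N[C@@H](c3ccccc3)C2C)cc1Cl`: 6000 nM
Compound 3, `CC1[C@H](c2ccccc2)NC(=O)N1S(=O)(=O)c1ccc(NC(=O)c2ccc(N)cc2)c(Cl)c1`: > 10000 nM

In a functional assay on A549 cells (Homo sapiens) for cytotoxicity, read by MTT assay (on this read-out lower numbers stand for stronger inhibition and higher numbers for weaker inhibition), compound 3 stands at the limit of > 10000 nM in this assay, at which 2 of the 3 values shown sit. That is a limit of the read-out, not a number. Among the compounds with values here, compound 2 is the only compound here with a measured number.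

Compound 4 is `CC1[C@H](c2ccccc2)NC(=O)N1S(=O)(=O)c1ccc(NC(=O)c2ccc([N+](=O)[O-])cc2)c(Cl)c1`. It differs from compound 3 by nitro in place of amino on an aromatic carbon. Within the data shown here, the single measured step, an at least 1.6-fold higher number from compound 2 to compound 3 (0.22 log units; that floor lies within the scatter), concerns a different change, ethoxy to 4-aminophenyl, and does not touch a nitro group; it lies within the scatter. Compound 1, which also carries a nitro group, shows only a limit. Nothing measured therefore points to a step beyond the scatter, and the step expected is a step that the limit leaves unreadable from compound 3 to compound 4. Compound 4 is estimated at 15000 nM, within 6000 nM to 40000 nM.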

Compound 4, half-maximal inhibitory concentration: > 10000 nM
Compound 4: a limit, no number (the forecaster's own chance of this, stated with the estimate: 80%); the middle value is on the limit's open side.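

In this assay, nitro in place of amino leaves compound 4 at a limit, not a number, just as compound 3 was, so this position has yet to give a measured value with either group. Replacing ethoxy with 4-nitrophenyl on the carbonyl carbon gives an at least 1.6-fold higher number from compound 2 to compound 4 (0.22 log units; that floor lies within the scatter). The steps from compound 3 and from compound 1 to compound 4 cannot be read, and the limit now holds most of the series: the limit of > 10000 nM in this assay, at which 3 of the 4 values shown sit.

Going by these compounds, whether nitro and amino differ at all in this assay stays open. So does whether a carboxylic acid or a hydroxyl group on that aromatic carbon would give a measured number.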